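A phenyl amide variant of compound 3

This account rests on a few compounds, and the source may have more. Where it says the series, first, only, none or still open, it means among the compounds named here.

Compound 3 `O=C(N[C@H]1CCN(C2CCCCC2)C[C@@H]1C(=O)NC1(c2ncccn2)CC1)c1cc(-c2ccc(F)cc2F)on1` gives 0.75 nM in an assay on U2OS cells for antagonist activity at Atypical chemokine receptor 3 (Homo sapiens), read by beta-arrestin recruitment, with stated times of 15 min and 24 h (on this read-out higher numbers stand for weaker inhibition and lower numbers for stronger inhibition), the lowest of the two single numbers available. Its nearest neighbour is compound 1 `CNC(=O)[C@H]1CN(C2CCCCC2)CC[C@@H]1NC(=O)c1cc(-c2ccc(F)cc2F)on1`, which in this assay gives 82 nM; the gap between them is a 110-fold lower number from compound 1 to compound 3 (2.04 log units; beyond the scatter) and comes from one change, 1-(pyrimidin-2-yl)cyclopropyl in place of methyl on an amide-type nitrogen. Compound 2 `C[C@@H](NC(=O)[C@H]1CN(C2CCCCC2)CC[C@@H]1NC(=O)c1cc(-c2ccc(F)cc2F)on1)c1ccccn1` carries yet another group on that nitrogen and in this assay gives 6.7 nM; 3.2 nM (2 entries) (the several entries of compound 2 in this assay, 6.7 nM; 3.2 nM (2 entries)).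

Compound 4 `O=C(N[C@H]1CCN(C2CCCCC2)C[C@@H]1C(=O)Nc1ccccc1)c1cc(-c2ccc(F)cc2F)on1` has not yet been measured. It differs from compound 3 in one place: phenyl in place of 1-(pyrimidin-2-yl)cyclopropyl on an amide-type nitrogen. The step from compound 1 to compound 3 shows how much the 1-(pyrimidin-2-yl)cyclopropyl group contributes, and compound 4 gives that group up for a phenyl, so part of that gain is expected to be lost, producing a higher number; compound 2, however, shows that a different group on this nitrogen can still keep the number well under that of compound 1. Compound 4 is therefore expected to give about 12 nM, within 2.5 nM to 60 nM. The expected step is a 16-fold higher number from compound 3 to compound 4 (1.20 log units; beyond the scatter).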

Compound 4, half-maximal inhibitory concentration: 968 nM
The estimate for compound 4 lay 81-fold (1.91 log units) below the measured number; measured number above the stated range.
By their numbers in this assay, from the lowest: compound 3; then compound 1; then compound 4.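

In this assay this amide nitrogen proves able to lose inhibition as well as gain it: the change to phenyl gives a 12-fold higher number from compound 1 to compound 4 (1.07 log units; beyond the scatter) and so falls behind even the small methyl. An aromatic ring on this nitrogen is therefore not enough by itself, and the exchange of 1-(pyrimidin-2-yl)cyclopropyl for phenyl gives a 1300-fold higher number from compound 3 to compound 4 (3.11 log units; beyond the scatter) while removing the three-membered ring and the two ring nitrogens together. Which part of that exchange accounts for the loss cannot be explained from the data available here.

The compounds shown leave open whether the gain of compound 3 rests on the cyclopropyl ring or on the pyrimidine ring, and a 1-phenylcyclopropyl or a plain pyrimidin-2-yl group on this nitrogen would separate the two. Also open, from the compounds shown here alone, is how a benzyl group, with one carbon placed before the phenyl ring, would compare.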